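Removing the methanesulfonamide on the aminopyridine

The source may report more compounds than this note shows. Statements on the series, on what has been measured and on what is new or still open speak of the compounds shown alone.

Compound 2 `CS(=O)(=O)Nc1ccc(-c2ccc(C(=O)N[C@H]3CN[C@@H](C(=O)Nc4ccc(Cl)c(C(F)(F)F)c4)C3)cc2)cn1` carries methylsulfonyl on a nitrogen on an aromatic ring. For the measured compounds named here, in a functional assay on K562 cells (Homo sapiens) for inhibition, read by MTT assay, with a stated time of 48 h (a lower number here means a stronger inhibitor, a higher number a weaker inhibitor), compound 2 gives 45000 nM, the highest of the two numbers so far. Its nearest neighbour is compound 1 `CC(=O)Nc1ccc(-c2ccc(C(=O)N[C@H]3CN[C@@H](C(=O)Nc4ccc(Cl)c(C(F)(F)F)c4)C3)cc2)cn1`, which in this assay gives 22800 nM; the step of a 2.0-fold higher number from compound 1 to compound 2 (0.30 log units; within the scatter) falls within the scatter, so the two acyl groups on that nitrogen cannot be ranked against each other.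

Compound 3 `Nc1ccc(-c2ccc(C(=O)N[C@H]3CN[C@@H](C(=O)Nc4ccc(Cl)c(C(F)(F)F)c4)C3)cc2)cn1` is the next point: the change is hydrogen in place of methylsulfonyl on a nitrogen on an aromatic ring. Going by the values given here, no measured pair covers loss of the whole substituent to a free amino group. Among the compounds with values here, the one step that bears on it, a 2.0-fold higher number from compound 1 to compound 2 (0.30 log units; within the scatter), shows that swapping acetyl for methylsulfonyl at this nitrogen changes the number only within the scatter, which gives no ground to expect a large movement in either direction. Compound 3 is therefore expected near the two measured values, with the step of a 1.5-fold lower number from compound 2 to compound 3 (0.18 log units; within the scatter) taken as within the scatter. The estimate for compound 3 is 30000 nM, in the range 10000 nM to 90000 nM.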

Compound 3, half-maximal inhibitory concentration: 9130 nM
Compound 3: the middle estimate sits 3.3-fold (0.52 log units) above what was measured; measured number outside the range, below it.
By their numbers in this assay, from the lowest: compound 3; then compounds 1 and 2 (each within the scatter of the next).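

Taking the whole substituent off the nitrogen on the aromatic ring moves the number in this assay beyond the scatter, with a 4.9-fold lower number from compound 2 to compound 3 (0.69 log units; beyond the scatter) and a 2.5-fold lower number from compound 1 to compound 3 (0.40 log units; beyond the scatter), both modest. This position therefore responds to the loss of the substituent, although the exchange of acetyl and methylsulfonyl gave no readable difference, with a 2.0-fold higher number from compound 1 to compound 2 (0.30 log units; within the scatter). Among these three compounds, the free amino group gives the lowest number, none goes against that order, and no measurement shown speaks to what lies behind this step.

The compounds shown leave open whether a single methyl or ethyl group on this nitrogen would keep the number near that of compound 3 or return it towards those of compound 1 and compound 2. Also open, going by these compounds, is whether the free amino group itself matters, which a hydroxyl group or a chlorine atom in its place could test, and whether a longer acyl chain such as propanoyl would stay within the scatter of acetyl.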